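The compounds below may be only part of what the source reports. "The series", "measured", "known", "first", "only" and "open" are said of these compounds alone.

Measured compounds:
- Compound 1, `CON1C[C@@H](NC(=O)OCCCCC2CCCCC2)C1=O`: in an assay on HEK293 cells for inhibition of N-acylethanolamine-hydrolyzing acid amidase (Homo sapiens), read by fluorescence, with stated times of 10 min and 50 min (a higher number here means a weaker inhibitor, a lower number a stronger inhibitor), compound 1 gives 56 nM
- Compound 2, `CSCCCON1C(=O)[C@@H](NC(=O)OCCCCC2CCCCC2)[C@@H]1C`: in this assay compound 2 gives 167 nM

Among the two measured compounds, compound 2 stands at the higher number, so it is the weaker inhibitor of the pair; the gap to compound 1 is larger than the usual scatter of repeated measurements. Among the measured compounds shown here, no step between measured compounds that differ in only one place is available, so the direction of any single change can only be guessed.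

Compound 3, `COC(=O)c1ccc(ON2C(=O)[C@@H](NC(=O)OCCCCC3CCCCC3)[C@@H]2C)cc1`, differs from compound 2 in one place: 4-(methoxycarbonyl)phenyl in place of 3-(methylsulfanyl)propyl on an oxygen. The group that leaves is a short chain; the group that enters is an aromatic ring carrying an ester. For the measured compounds named here, nothing among the measured compounds tells how this change plays out in this assay. The expectation is therefore cautious: a step from compound 2 to compound 3 of modest size, more likely downward than upward, but possibly none beyond the scatter, as expressed by a 1.4-fold lower number from compound 2 to compound 3 (0.14 log units; within the scatter). Compound 3 is expected to give about 120 nM in this assay, with a range from 30 nM to 500 nM.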

Compound 3, half-maximal inhibitory concentration: 17 nM
Compound 3: the middle estimate sits 7.1-fold (0.85 log units) above what was measured, and the stated range ends above it.
By their numbers in this assay, from the lowest: compound 3; then compound 1; then compound 2.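

The oxygen on the amide-type nitrogen in a ring proves to be a place where the choice of group matters in this assay: putting 4-(methoxycarbonyl)phenyl in place of 3-(methylsulfanyl)propyl gives a 9.8-fold lower number from compound 2 to compound 3 (0.99 log units; beyond the scatter). With the rest of the molecule unchanged, this position accepts an aromatic ring carrying an ester, and here the group with 10 heavy atoms gives a stronger inhibitor than the chain with 5. Nothing measured here explains this drop, and a single step cannot separate the contribution of the ring from that of the ester.

A plain phenyl group on the same oxygen would show how much of the step goes with the ring alone, while a carboxylic acid in place of the methyl ester would test whether the ester itself matters. Also open, on these data alone, is whether the same exchange would move the number in the same direction on the core of compound 1.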